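Replacing a Benzyloxy Group with Methyl on a Carbonyl

A few compounds are considered here, and "the series" means these few. Any claim that something is new, unique, unknown or untested is made for them only; others in the source may bear on it.

Measured so far:
Compound 1, `C=CCOC(=O)SCCCCCCNC(=O)c1cc(-c2ccncc2)n[nH]1`: 32900 nM
Compound 2, `O=C(OCc1ccccc1)SCCCCCCNC(=O)c1cc(-c2ccncc2)n[nH]1`: 18200 nM

In a functional assay on HCT-116 cells (Homo sapiens) for inhibition, read by MTT assay, with a stated time of 96 h (a lower number here means a stronger inhibitor of growth, a higher number a weaker inhibitor of growth), compound 1 gives 32900 nM and compound 2 gives 18200 nM. Compound 2 has the lower of the two numbers, but the step of a 1.8-fold lower number from compound 1 to compound 2 (0.26 log units; within the scatter) lies within the scatter, so the two cannot be told apart on these data.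

Compound 3, `CC(=O)SCCCCCCNC(=O)c1cc(-c2ccncc2)n[nH]1`, is not yet measured. It differs from compound 2 by methyl in place of benzyloxy on a carbonyl carbon. Among the measured compounds shown here, the only measured step, a 1.8-fold lower number from compound 1 to compound 2 (0.26 log units; within the scatter), changed a group in the same region of the chain and moved the number little. It is a different exchange, so it bears only loosely on the present one. For the measured compounds named here, no measured pair shows this change directly.

Compound 3 is therefore expected near compound 2, with the step of a 1.6-fold higher number from compound 2 to compound 3 (0.22 log units; within the scatter) and an estimated value of 30000 nM, ranging from 12000 nM to 75000 nM.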

Compound 3, concentration for 50% growth inhibition: 41100 nM
The estimate for compound 3 lay 1.4-fold (0.14 log units) below the measured number; low and high end bracket the measured number.
By their numbers in this assay, from the lowest: compounds 2, 1 and 3 (each within the scatter of the next, the first and the last beyond it).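

In this assay, methyl in place of benzyloxy on the carbonyl carbon gives a 2.3-fold higher number from compound 2 to compound 3 (0.35 log units; beyond the scatter), a modest step and the first at this position that lies beyond the scatter. Methyl in place of allyloxy gives a 1.2-fold higher number from compound 1 to compound 3 (0.10 log units; within the scatter), which lies within the scatter, so compound 1 and compound 3 cannot be told apart, and the benzyloxy group of compound 2 separates from methyl while the allyloxy group of compound 1 does not. Nothing in the available data offers an explanation for this difference between the two exchanges.

The compounds shown leave open how an amine or a carboxylic acid on this carbonyl carbon would compare with methyl and benzyloxy. Among the compounds shown here, they also leave open whether the step from benzyloxy to methyl would hold with a longer chain in place of the one that all three compounds share.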